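The compounds below may be only part of what the source reports. "The series", "measured", "known", "first", "only" and "open" are said of these compounds alone.

Compound 3 `O=c1c(Cl)c(N2CCC(c3ccccc3)CC2)ccn1CC1CC1` gives the lowest of the three values in a functional assay on CHO cells for positive allosteric modulation of metabotropic glutamate receptor 2 (Homo sapiens), with a stated time of 30 min (on this read-out lower numbers stand for smaller maximal responses and higher numbers for larger maximal responses), namely 259%, while compound 2 `N#Cc1c(N2CCC(c3ccccc3)CC2)ccn(CC2CC2)c1=O` gives 309% and compound 1 `CC(C)Cn1ccc(N2CCC(c3ccccc3)CC2)c(C#N)c1=O` gives 316% in this assay. The step of a number 50 percentage points lower from compound 2 to compound 3 (beyond the scatter) is large, whereas a number 7 percentage points lower from compound 1 to compound 2 (within the scatter) stays within the scatter. Compound 4 `CC(C)Cn1ccc(N2CCC(c3ccccc3)CC2)c(Cl)c1=O` differs from compound 3 by isopropyl in place of cyclopropyl on a saturated chain carbon bound to an aromatic nitrogen. For the measured compounds named here, the only measured step that bears on this change is a number 7 percentage points lower from compound 1 to compound 2 (within the scatter), the same exchange run in the opposite direction, and it did not move the read-out beyond the scatter. Compound 4 is therefore expected to show a number 6 percentage points higher from compound 3 to compound 4 (within the scatter) in this assay, no change beyond the scatter. The estimate for compound 4 in this assay is 265%, with a range from 225% to 305%.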

Compound 4, largest response reached (Emax), in percent of the reference or control that the assay uses: 260%
Estimate against measurement, compound 4: 5 percentage points above; the measured number falls inside the stated range.
By their numbers in this assay, from the lowest: compounds 3 and 4 (each within the scatter of the next); then compounds 2 and 1 (each within the scatter of the next).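

In this assay, isopropyl in place of cyclopropyl gives a number 1 percentage points higher from compound 3 to compound 4 (within the scatter), so this change leaves the read-out unmoved with chloro on the aromatic carbon, as it did with cyano: the same change on two cores in this assay, a number 7 percentage points lower (within the scatter) from compound 1 to compound 2 and a number 1 percentage points lower (within the scatter) from compound 4 to compound 3, 6 percentage points apart, within the scatter of two such steps. Chloro in place of cyano, so far seen only with cyclopropyl, also lowers the maximal response with isopropyl, giving a number 56 percentage points lower from compound 1 to compound 4 (beyond the scatter), and the two steps agree: the same change on two cores in this assay, a number 50 percentage points lower (beyond the scatter) from compound 2 to compound 3 and a number 56 percentage points lower (beyond the scatter) from compound 1 to compound 4, 6 percentage points apart, within the scatter of two such steps. The compounds shown leave open how a longer chain or an amine on the saturated chain carbon would read, and how bromo or methoxy on the aromatic carbon would compare with chloro and cyano.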